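The source may hold more compounds than are shown below. What is called first, only, known or untested is meant among the compounds shown, and "the series" means these compounds.

Of the compounds shown here, two sharing one core have been measured in a functional assay on PC-3 cells (Homo sapiens) for inhibition, read by sulforhodamine B assay, with a stated time of 48 h, tested at 10 uM; on this read-out lower numbers stand for less inhibition and higher numbers for more inhibition at the one concentration tested (going by the name of the read-out). Compound 1 `Clc1ccc(-c2cn3ccnc3c(-c3ccc4ncn(C5CCCCC5)c4c3)n2)cc1` carries a 4-chlorophenyl group and gives 24.6%. Compound 2 `Brc1ccc(-c2cn3ccnc3c(-c3ccc4ncn(C5CCCCC5)c4c3)n2)cc1` carries a 4-bromophenyl group in the same place; in this assay compound 2 gives 42.4%. Within the data shown here, the only measured step is a number 17.8 percentage points higher from compound 1 to compound 2 (beyond the scatter), a change of one halogen for another on the same ring. On these two numbers compound 2 stands highest, its nearest neighbour being compound 1 at a gap beyond the scatter.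

Compound 3 `c1csc(-c2cn3ccnc3c(-c3ccc4ncn(C5CCCCC5)c4c3)n2)c1` is the next compound to be measured. Its difference from compound 2 is thiophen-2-yl in place of 4-bromophenyl on an aromatic carbon. Among the measured compounds shown here, no measured step swaps the whole aryl group, so the step from compound 1 to compound 2 bears only indirectly: it shows that a change at this position moved the read-out by a modest amount. A shift of similar modest size, in either direction, is therefore expected, with the lower direction somewhat more likely because the bromo variant in compound 2 gave 42.4%, the highest so far.

Compound 3 is estimated to give 30% in this assay, within 10% to 55%, that is an expected step of a number 12.4 percentage points lower from compound 2 to compound 3 (beyond the scatter).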

Compound 3, a percentage reported as inhibition, at one concentration (the size of the read-out at that concentration, not a potency): 49.1%
Estimate against measurement, compound 3: 19.1 percentage points below; measured number inside the range.
By their numbers in this assay, from the lowest: compound 1; then compounds 2 and 3 (each within the scatter of the next).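

In this assay, among these compounds, this is the first change of the whole aryl group at this position, and the step, a number 6.7 percentage points higher from compound 2 to compound 3 (within the scatter), leaves thiophen-2-yl and 4-bromophenyl indistinguishable, so a six-membered aromatic ring of carbon only carrying a halogen is not needed here for a read-out at this level. Among the compounds shown here, the other step, a number 24.5 percentage points higher from compound 1 to compound 3 (beyond the scatter), shows that compound 1 lies apart from both compound 2 and compound 3, making 4-chlorophenyl the only one of the three groups whose number separates from the others, even though the smaller thiophen-2-yl, with its one sulfur, differs from 4-bromophenyl far more in structure than 4-chlorophenyl does. Nothing measured accounts for the gap between the two halogen-bearing groups, or for the match between thiophen-2-yl and 4-bromophenyl.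

On these data alone, it remains open what a plain phenyl ring, a furan-2-yl ring or a phenyl ring carrying an amine would give at this place, and so whether the read-out follows the ring or the group on it. These single-concentration percentages also leave open how the three compounds would rank by potency.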